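Permeability notes on compounds 1 to 3

This account rests on a few compounds, and the source may have more. Where it says the series, first, only, none or still open, it means among the compounds named here.

Within the data shown here, compound 2 `COc1ccc(-c2nc3ccccc3s2)cc1NC(=O)c1cnccc1Cl` stands lowest of the two numbers so far in an ADME assay for permeability, using PAMPA (on this read-out higher numbers stand for higher permeability and lower numbers for lower permeability), where compound 2 gives 121 10^-6 cm/s. Among the measured compounds shown here, its nearest neighbour is compound 1 `O=C(Nc1cccc(-c2nc3ccccc3s2)c1)c1cnccc1Cl`, which in this assay gives 732 10^-6 cm/s; the single step between them, a 6.0-fold lower number from compound 1 to compound 2 (0.78 log units; beyond the scatter), is methoxy in place of hydrogen on an aromatic carbon. Compound 3 `O=C(Nc1cc(-c2nc3ccccc3s2)ccc1F)c1cnccc1Cl` is the next compound to be measured in this assay. It differs from compound 2 by fluoro in place of methoxy on an aromatic carbon. For the measured compounds named here, only one measured step bears on this change, a 6.0-fold lower number from compound 1 to compound 2 (0.78 log units; beyond the scatter), and the methoxy that entered there leaves again here while fluoro takes its place. An upward step is therefore expected, a 3.7-fold higher number from compound 2 to compound 3 (0.57 log units; beyond the scatter), falling somewhat short of a full return to the number of compound 1. Compound 3 is thus expected at 450 10^-6 cm/s, with a range from 200 10^-6 cm/s to 850 10^-6 cm/s.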

Compound 3, apparent permeability: 306 10^-6 cm/s
Compound 3: the middle estimate sits 1.5-fold (0.17 log units) above what was measured; measured number inside the range.
By their numbers in this assay, from the lowest: compound 2; then compound 3; then compound 1.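

At this place, ortho to a large group and para to a 1,3-benzothiazol-2-yl group, the lower number in this assay does not come with methoxy alone: fluoro, a single heavy atom with no hydrogen-bond acceptor counted, still gives a 2.4-fold lower number from compound 1 to compound 3 (0.38 log units; beyond the scatter). Set against methoxy, fluoro gives a 2.5-fold higher number from compound 2 to compound 3 (0.40 log units; beyond the scatter), so the number comes back only part of the way, and the three compounds run from hydrogen down through fluoro to methoxy, with every step beyond the scatter. No measurement at hand gives a reason for these steps.

Among these compounds, with only two groups at this place, it stays open whether the number follows the count of heavy atoms, the hydrogen-bond acceptor or neither. Also open, as far as these compounds go, is how an amine, a carboxylic acid or a longer chain such as ethoxy would stand here.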